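The source may report more compounds than this note shows. Statements on the series, on what has been measured and on what is new or still open speak of the compounds shown alone.

Measured in an assay for inhibition of apolipoprotein B-100 (Homo sapiens), tested at 100 nM; on this read-out lower numbers stand for stronger inhibition and higher numbers for weaker inhibition:
compound 1 `Cc1cccc(C(=O)Nc2ccc3c(c2)CC(NS(=O)(=O)c2ccccc2)C3)c1-c1ccc(Cl)cc1` gives 2.4 nM
compound 2 `Cc1cccc(C(=O)Nc2ccc3c(c2)CC(NS(=O)(=O)c2cccs2)C3)c1-c1ccc(Cl)cc1` gives 3 nM
compound 3 `Cc1cccc(C(=O)Nc2ccc3c(c2)CC(CNS(C)(=O)=O)C3)c1-c1ccc(C(F)(F)F)cc1` gives 6.5 nM

For the measured compounds named here, compound 3 holds the highest of the three numbers; compound 1 and compound 2 both stand lower, beyond the scatter, but each of them differs from compound 3 in more than one place, so no single-point step links them to it. Going by the values given here, the only single-point step on record, a 1.3-fold higher number from compound 1 to compound 2 (0.10 log units; within the scatter), concerns the group on the sulfonyl sulfur and does not touch the part changed next.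

Compound 4 `Cc1cccc(C(=O)Nc2ccc3c(c2)CC(CNS(C)(=O)=O)C3)c1-c1ccc(Cl)cc1` differs from compound 3 by chloro in place of trifluoromethyl on an aromatic carbon. Among the compounds with values here, no measured step bears directly on this exchange. What the values show is that compound 1 and compound 2, both carrying chloro on that ring, sit below compound 3 in this assay, yet their sulfonamide portion also differs, so the share of the chloro in that gap cannot be separated out. The step from compound 3 to compound 4 is therefore expected to be modest, a 1.4-fold lower number from compound 3 to compound 4 (0.16 log units; within the scatter), leaning toward a lower number but not confidently beyond the scatter. Compound 4 is estimated at 4.5 nM, within a range of 2 nM to 10 nM.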

Compound 4, half-maximal inhibitory concentration: 16 nM
For compound 4 the middle estimate is 3.6-fold (0.55 log units) below the measured one, and the stated range ends below it.
By their numbers in this assay, from the lowest: compounds 1 and 2 (each within the scatter of the next); then compound 3; then compound 4.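

In this assay, chloro in place of trifluoromethyl on the aromatic carbon para to a large group gives a 2.5-fold higher number from compound 3 to compound 4 (0.39 log units; beyond the scatter), so this position responds to the exchange, with trifluoromethyl holding the lower number in this pair. With chloro held constant on that ring, the sulfonamide portion can now be read directly: (methanesulfonamido)methyl in place of (phenylsulfonyl)amino gives a 6.7-fold higher number from compound 1 to compound 4 (0.82 log units; beyond the scatter), and in place of ((thiophen-2-yl)sulfonyl)amino it gives a 5.3-fold higher number from compound 2 to compound 4 (0.73 log units; beyond the scatter). No supporting data accompany these steps, so they remain observations without an explanation.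

Still open, going by these compounds, is whether trifluoromethyl also gives the lower number when paired with the (phenylsulfonyl)amino group, and how a methoxy group or a nitrile would fare on the same aromatic carbon. The compounds shown also cannot separate the contribution of the methyl on sulfur from that of the link to the saturated ring carbon.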